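The compounds below may be only part of what the source reports. "The series", "measured", "known", "first", "only" and "open" are said of these compounds alone.

Measured compounds in this test:

Compound 1 `Nc1cc(N)c2nc(-c3ccccc3)c(Oc3ccc(F)cc3)nc2c1`: 81300 nM
Compound 2 `COc1cc(CNc2nc3cc(N)cc(N)c3nc2-c2ccccc2)cc(OC)c1OC`: < 50200 nM (a limit)
Compound 3 `CCOC(=O)[C@H](CCC(=O)O)NC(=O)c1ccc(Oc2nc3cc(N)cc(N)c3nc2-c2ccccc2)cc1`: < 100000 nM (a limit)

Among the measured compounds shown here, in a functional assay on NCI-H322M cells (Homo sapiens) for inhibition, read by sulforhodamine B assay, with a stated time of 48 h (on this read-out higher numbers stand for lower toxicity in this test and lower numbers for higher toxicity in this test), compound 1 gives 81300 nM, the only number among the three values shown. For compound 2 the result is a limit of the assay, < 50200 nM. For compound 3 the result is likewise a limit, < 100000 nM. For the measured compounds named here, the two limits are summarized as the limit of < 100000 nM in this assay, at which 1 of the 3 values shown sits, and (the limit of < 50200 nM in this assay, at which 1 of the 3 values shown sits); neither gives a step against compound 1, and no pair of measured compounds differs in one place, so no measured step is available in this assay.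

Compound 4 `COc1ccc(Sc2nc3cc(N)cc(N)c3nc2-c2ccccc2)cc1` is not yet measured. Relative to compound 1 the change is (4-methoxyphenyl)sulfanyl in place of 4-fluorophenoxy on an aromatic carbon. Going by the values given here, with no measured step to lean on, the expected step from compound 1 to compound 4 in this assay is small, a 1.4-fold lower number from compound 1 to compound 4 (0.13 log units; within the scatter), and not expected to go beyond the scatter in either direction. For compound 4 the estimate in this assay is 60000 nM, with a range from 20000 nM to 150000 nM.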

Compound 4, concentration lethal to 50% of the cells: < 100000 nM
Compound 4: a limit, no number (the forecaster's own chance of this, stated with the estimate: 35%); the middle value does not contradict the limit.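

Among the compounds shown here, compound 4 gives only a limit, < 100000 nM, not a number, so no step from compound 1 to compound 4 can be read. The compounds shown leave open whether (4-methoxyphenyl)sulfanyl in place of 4-fluorophenoxy on an aromatic carbon shifts the result in this assay, and in which direction.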